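Lengthening a Side Chain on a Shared Sulfonate Core

This account rests on a few compounds, and the source may have more. Where it says the series, first, only, none or still open, it means among the compounds named here.

Two measured compounds share one core and differ only in the chain on the outer ring. Compound 1 `CCNC(=O)Nc1cccc(S(=O)(=O)Oc2ccccc2C)c1` gives 44000 nM in a functional assay on HT-29 cells (Homo sapiens) for cytotoxicity, read by sulforhodamine B assay, with a stated time of 48 h; on this read-out lower numbers stand for stronger inhibition and higher numbers for weaker inhibition. Compound 2 `CCNC(=O)Nc1cccc(S(=O)(=O)Oc2ccccc2CC)c1` gives 33000 nM in this assay. Among the compounds with values here, the only step known so far is a 1.3-fold lower number from compound 1 to compound 2 (0.12 log units; within the scatter), so compound 2 stands apart from compound 1 by no more than the assay's own scatter can produce.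

Compound 3 `CCCc1ccccc1OS(=O)(=O)c1cccc(NC(=O)NCC)c1` carries the chain one bond further: methyl in place of hydrogen on a saturated chain carbon, two bonds along the chain from an aromatic carbon. The step from compound 1 to compound 2 is the only one that bears on this change, and because that step a 1.3-fold lower number from compound 1 to compound 2 (0.12 log units; within the scatter) stayed within the scatter, no movement beyond the scatter is expected in this assay either, which means an expected step of a 1.2-fold lower number from compound 2 to compound 3 (0.07 log units; within the scatter). Compound 3 is therefore estimated to give about 28000 nM, with an expected range from 12000 nM to 65000 nM.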

Compound 3, half-maximal inhibitory concentration: 25000 nM
Estimate against measurement, compound 3: 1.1-fold (0.05 log units) above; the measured number falls inside the stated range.
By their numbers in this assay, from the lowest: compounds 3, 2 and 1 (each within the scatter of the next).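

In this assay the second extension of the chain, ethyl to propyl, gives a 1.3-fold lower number from compound 2 to compound 3 (0.12 log units; within the scatter) as its step, so a methyl on a saturated chain carbon, two bonds along the chain from an aromatic carbon, brings no movement beyond the scatter. Taken as a single change, the two extensions together give a 1.8-fold lower number from compound 1 to compound 3 (0.25 log units; within the scatter) as their step, so methyl, ethyl and propyl cannot be told apart here. No measurement on hand offers a reason for these small steps.

A longer chain such as butyl or hexyl may or may not stay within the scatter. On these data alone, how an amine or a carboxylic acid on this chain would read in this assay also remains open.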